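The compounds below may be only part of what the source reports. "The series", "measured", "known", "first", "only" and "open" are said of these compounds alone.

Measured so far:
compound 1, `COc1ccc2c(c1)nc(/C=C1\SC(=S)N(CC(=O)O)C1=O)n2Cc1ccc(C)cc1`, gives 3640 nM in a functional assay on PC-3 cells (Homo sapiens) for cytotoxicity, read by MTT assay, with a stated time of 48 h; on this read-out lower numbers stand for stronger inhibition and higher numbers for weaker inhibition;
compound 2, `Cc1ccc(Cn2c(/C=C3\SC(=S)NC3=O)nc3ccccc32)cc1`, gives 9780 nM;
compound 3, `COc1ccc2c(c1)nc(/C=C1\SC(=S)N(CC(=O)O)C1=O)n2Cc1ccccc1F`, gives 24700 nM.

Compound 3 arises from compound 1 by one change, (2-fluorophenyl in place of 4-methylphenyl on a saturated chain carbon bound to an aromatic nitrogen), and this brought a 6.8-fold higher number from compound 1 to compound 3 (0.83 log units; beyond the scatter). Compound 2 and compound 1 share the same kind of scaffold, but the difference between the two cores is not broken down here. Compound 4, `O=C1NC(=S)S/C1=C\c1nc2ccccc2n1Cc1ccccc1F`, has not yet been measured; it arises from compound 2 by the same change, (2-fluorophenyl in place of 4-methylphenyl on a saturated chain carbon bound to an aromatic nitrogen), at the same place. Because a 6.8-fold higher number from compound 1 to compound 3 (0.83 log units; beyond the scatter) was the outcome when this change was made once before, a step of about the same size is expected from compound 2 to compound 4, namely a 5.6-fold higher number from compound 2 to compound 4 (0.75 log units; beyond the scatter). Compound 4 is thus estimated at 55000 nM, likely between 15000 nM and 200000 nM.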

Compound 4, half-maximal inhibitory concentration: > 50000 nM
Compound 4: only a limit was reported (the forecaster's own chance of this, stated with the estimate: 20%); the middle value lies beyond the limit too.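

On the core of compound 2, putting 2-fluorophenyl in place of 4-methylphenyl gave an at least 5.1-fold higher number from compound 2 to compound 4 (0.70 log units; beyond the scatter) in this assay, the same direction as on the core of compound 1. Compound 4 gives > 50000 nM, which is a limit of the assay and not a number. The change thus carries over in direction, but whether its size is the same on both cores stays unsettled: the same change on two cores in this assay, a 6.8-fold higher number (0.83 log units; beyond the scatter) from compound 1 to compound 3 and an at least 5.1-fold higher number (0.70 log units; beyond the scatter) from compound 2 to compound 4; the limit leaves it open whether they differ

The compounds shown cover only these two groups at this place, on only two cores. Still open, on these data alone, is how an unsubstituted phenyl, a 4-fluorophenyl or an amine on a longer chain would fare there.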